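The compounds below may be only part of what the source reports. "The series", "measured", "known", "first", "only" and "open" are said of these compounds alone.

Measured compounds:
- compound 1 `CCOc1cc(Cl)c(C(=O)NC(=O)Nc2nc3ccc(S(=O)(=O)C4CCN(C)CC4)cc3s2)cc1-n1cccn1` gives 23 nM in a functional assay on CHO cells for agonist activity at hydroxycarboxylic acid receptor 1 (Homo sapiens), read by cAMP accumulation; on this read-out higher numbers stand for an effect only at larger amounts of compound and lower numbers for an effect already at smaller amounts
- compound 2 `CN1CCC(S(=O)(=O)c2ccc3nc(NC(=O)NC(=O)c4cc(-n5cccn5)c(F)cc4Cl)sc3c2)CC1` gives 3600 nM in this assay
- compound 3 `CN1CCC(S(=O)(=O)c2ccc3nc(NC(=O)NC(=O)c4cc(-n5cccn5)ccc4Cl)sc3c2)CC1` gives 7000 nM in this assay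

Compound 1 has the lowest number of the three in this assay, and its steps to both others lie beyond the scatter, so it is the most potent compound here. The change that leads away from it is a 160-fold higher number from compound 1 to compound 2 (2.19 log units; beyond the scatter) and a 300-fold higher number from compound 1 to compound 3 (2.48 log units; beyond the scatter), both large; between compound 2 and compound 3 the difference is a 1.9-fold higher number from compound 2 to compound 3 (0.29 log units; within the scatter), which is within the scatter.

Compound 4 `CCOc1cc(Cl)c(C(=O)NC(=O)Nc2nc3ccc(CN4CCN(C)CC4)cc3s2)cc1-n1cccn1` has not yet been measured. It differs from compound 1 at a different place: (4-methylpiperazin-1-yl)methyl in place of (1-methylpiperidin-4-yl)sulfonyl on an aromatic carbon. Among the compounds with values here, none of the measured steps touches this part of the core of compound 1; all three concern the ethoxy group, which compound 4 keeps. Within the data shown here, there is therefore no measured step that bears directly on this change, and the expectation rests only on the fact that compound 4 retains everything that set compound 1 apart from compound 2 and compound 3. The replaced group is somewhat smaller and loses the sulfonyl, so a change of some size in either direction is possible. For compound 4 in this assay the estimate is 70 nM, with a range from 10 nM to 500 nM; this expected step is a 3.0-fold higher number from compound 1 to compound 4 (0.48 log units; beyond the scatter).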

Compound 4, half-maximal effective concentration: 19 nM
Beside the measured number, compound 4's estimate is 3.7-fold (0.57 log units) above it; measured number inside the range.
By their numbers in this assay, from the lowest: compounds 4 and 1 (each within the scatter of the next); then compounds 2 and 3 (each within the scatter of the next).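

In this assay, putting (4-methylpiperazin-1-yl)methyl in place of (1-methylpiperidin-4-yl)sulfonyl gives a 1.2-fold lower number from compound 1 to compound 4 (0.08 log units; within the scatter), so this exchange leaves the read-out where it was. Within the data shown here, the earlier compounds varied only the ethoxy group, whereas this pair is the first to probe this position on the six-membered aromatic ring, and it shows that the sulfonyl link is not required for an effect at small amounts of compound when the ethoxy group is kept. The two groups share a six-membered non-aromatic ring with a methyl group on its nitrogen, but nothing available explains why one can stand in for the other.

The compounds shown cannot tell whether that methylated ring nitrogen matters, which a morpholin-4-ylmethyl group or a carboxylic acid at this position would help to test. They also leave open whether (4-methylpiperazin-1-yl)methyl would still match the sulfonyl group with fluoro or hydrogen in place of ethoxy, the two changes that raised the number so sharply in the sulfonyl series.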